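The source may hold more compounds than are shown below. What is called first, only, known or untested is meant among the compounds shown, and "the series" means these compounds.

Compound 1 `COC(CCn1cnc2c(NCc3ccc(C(=O)Nc4ccccc4N)cc3)nc(Cl)nc21)OC` — 11.9% in a functional assay on HCT-116 cells (Homo sapiens) for antiproliferative activity, read by CCK-8 assay, with a stated time of 72 h, tested at 8 uM; a lower number here means a weaker effect, a higher number a stronger effect of the compound at the concentration tested
Compound 2 `Cc1ccc(Nc2nc(Cl)nc3c2ncn3Cc2ccc(C(=O)Nc3ccccc3N)cc2)cc1` — 81.5% in this assay

Of these two, compound 2 stands highest, and its gap to compound 1 lies well beyond the scatter. Compound 3 `Nc1ccccc1NC(=O)c1ccc(Cn2cnc3c(Nc4ccccc4)nc(Cl)nc32)cc1` has not yet been measured in this assay. It differs from compound 2 by hydrogen in place of methyl on an aromatic carbon. Going by the values given here, no measured pair shows this change, so the size of the step rests on judgement alone. The step is estimated to be small and downward, perhaps no larger than the scatter: a number 11.5 percentage points lower from compound 2 to compound 3 (beyond the scatter). Compound 3 is therefore expected to give about 70%, in a range from 45% to 88%.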

Compound 3, a percentage reported as inhibition, at one concentration (the size of the read-out at that concentration, not a potency): 83.5%
For compound 3 the middle estimate is 13.5 percentage points below the measured one, and the stated range covers the measured number.
By their numbers in this assay, from the lowest: compound 1; then compounds 2 and 3 (each within the scatter of the next).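

Replacing methyl with hydrogen, which turns 4-methylphenyl into phenyl, gives a number 2 percentage points higher from compound 2 to compound 3 (within the scatter) in this assay, so at this position, para to a large group, the read-out does not separate the two. The earlier compounds shown here offered no pair that isolated a change at this place. No measured evidence accompanies this result to explain it. Still open, on these data alone, is whether a methoxy group, a chlorine atom or an amine at this carbon would keep the read-out. A single concentration also leaves unresolved whether the effect of compound 2 and compound 3 would differ at any other concentration.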